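The source may report more compounds than this note shows. Statements on the series, on what has been measured and on what is new or still open speak of the compounds shown alone.

- Compound 1 `COc1ccc(-c2nnc(SCCn3c([N+](=O)[O-])cnc3C)o2)cc1`: 5800 nM
- Compound 2 `Cc1ncc([N+](=O)[O-])n1CCSc1nnc(-c2ccc([N+](=O)[O-])cc2)o1`: 4100 nM
- Compound 3 `Cc1ncc([N+](=O)[O-])n1CCSc1nnc(-c2ccccc2Cl)o1`: 15600 nM

These values come from a functional assay on HepG2 cells (Homo sapiens) for cytotoxicity, read by MTT assay, with a stated time of 48 h; a higher number here means a weaker inhibitor, a lower number a stronger inhibitor. Compound 1 stands level with compound 2 within the scatter, while compound 3 stands apart at the high end. Compound 4 `Cc1cccc(-c2nnc(SCCn3c([N+](=O)[O-])cnc3C)o2)c1O` has yet to be measured. Its difference from compound 1 is 2-hydroxy-3-methylphenyl in place of 4-methoxyphenyl on an aromatic carbon. Among the compounds with values here, two measured steps bear on this change: a 1.4-fold lower number from compound 1 to compound 2 (0.15 log units; within the scatter), and a 2.7-fold higher number from compound 1 to compound 3 (0.43 log units; beyond the scatter). Within the data shown here, the second is the closer guide, as it also replaces the whole 4-methoxyphenyl, but no measured compound carries a hydroxy group. A rise no larger than that second step is therefore expected in this assay. The estimated step is a 1.6-fold higher number from compound 1 to compound 4 (0.21 log units; within the scatter). The expected value for compound 4 is 9500 nM, with an estimated range from 3500 nM to 22000 nM.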

Compound 4, half-maximal inhibitory concentration: 8700 nM
Estimate against measurement, compound 4: 1.1-fold (0.04 log units) above, and the stated range covers the measured number.
By their numbers in this assay, from the lowest: compounds 2, 1, 4 and 3 (each within the scatter of the next, the first and the last beyond it).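

In this assay, within the data shown here, a phenyl group carrying a hydrogen-bond donor appears at this position for the first time, and 2-hydroxy-3-methylphenyl gives two steps within the scatter (a 1.5-fold higher number from compound 1 to compound 4 (0.18 log units; within the scatter); a 1.8-fold lower number from compound 3 to compound 4 (0.25 log units; within the scatter)). Compound 4 therefore cannot be separated from either compound 1 or compound 3, although those two stand apart beyond the scatter. No evidence is available to explain these numbers.

Going by these compounds, the hydroxy and methyl groups enter together, so their separate contributions remain open. So does the outcome with an amine, a carboxylic acid or a longer chain on the phenyl ring.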